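Cyano to Carbamoyl Exchange Under a Solubility Limit

The source may hold more compounds than are shown below. What is called first, only, known or untested is meant among the compounds shown, and "the series" means these compounds.

The measured compounds are few. In a physicochemical assay for solubility, using the shake flask method, in simulated intestinal fluid, measured as kinetic solubility, with a stated time of 2 h, at 25 degrees C, at pH 6.5 (on this read-out higher numbers stand for higher solubility and lower numbers for lower solubility), compound 1 `Cc1nc(C#N)c(N)c2c1C(=O)N(Cc1ccccc1)C2=O` reaches only the limit < 5000 nM. In this assay compound 2 `Cc1nc(C(N)=O)c(N)c2c1C(=O)N(Cc1ccccc1)C2=O` likewise sits at the limit < 5000 nM. In this assay compound 3 `Cc1noc(-c2nc(C)c3c(c2N)C(=O)N(Cc2ccc(C#N)cc2)C3=O)n1` also returns the limit < 5000 nM.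

Compound 1 and compound 2 differ by one change, (carbamoyl in place of cyano on an aromatic carbon). The step in this assay is a step that the two limits leave unreadable from compound 1 to compound 2, so its size stays hidden. Compound 4 `Cc1noc(-c2nc(C)c3c(c2N)C(=O)N(Cc2ccc(C(N)=O)cc2)C3=O)n1` carries the same kind of change against compound 3, namely (carbamoyl in place of cyano on an aromatic carbon); here the place is a six-membered aromatic ring of carbon only, para to a large group, whereas in compound 1 the ring holds one nitrogen within a fused system of two rings. The difference between the two cores is not broken down here.

Since all readings stop at the same point, the expectation for compound 4 rests on (the limit of < 5000 nM in this assay, at which 3 of the 3 values shown sit). The expected step from compound 3 to compound 4 is a step that the limit leaves unreadable from compound 3 to compound 4. Compound 4 is therefore estimated at 3000 nM in this assay, within 500 nM to 9000 nM.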

Compound 4, solubility: < 5000 nM
Compound 4 gave a limit, no number (the forecaster's own chance of this, stated with the estimate: 70%); the middle value lies beyond the limit too.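

In this assay, within the data shown here, compound 3 and compound 4 both stop at a limit, so the exchange of cyano for carbamoyl gives no step that can be read between them. The readings shown all stay at one point: the limit of < 5000 nM in this assay, at which 4 of the 4 values shown sit.

The compounds shown leave open how far any of the four lies from that limit, and whether this exchange shifts the reading at all.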